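Ethyl to tert-Butyl Ester Swap on a Pyridyl Dihydropyridine

The source may hold more compounds than are shown below. What is called first, only, known or untested is meant among the compounds shown, and "the series" means these compounds.

Compound 1 `CCO/C(O)=C1\C(C)=NC(C)=C([N+](=O)[O-])C1c1ccncc1` and compound 2 `CC1=NC(C)=C([N+](=O)[O-])C(c2ccncc2)/C1=C(\O)OC(C)(C)C` share one core and differ only in tert-butyl in place of ethyl on an oxygen on an unsaturated carbon. In a functional assay (cardiac atrium) for agonist activity, with Cavia porcellus as the target (on this read-out lower numbers stand for an effect already at smaller amounts and higher numbers for an effect only at larger amounts of compound), compound 1 gives 6460 nM, and compound 2 gives 2820 nM, so a 2.3-fold lower number from compound 1 to compound 2 (0.36 log units; beyond the scatter). Compound 3 `CCO/C(O)=C1\C(C)=NC(C)=C([N+](=O)[O-])C1c1ccccn1` carries a different core, separated from that of compound 1 by pyridin-2-yl in place of pyridin-4-yl on a saturated ring carbon; in this assay compound 3 gives 22800 nM, and a 3.5-fold higher number from compound 1 to compound 3 (0.55 log units; beyond the scatter). Compound 4 `CC1=NC(C)=C([N+](=O)[O-])C(c2ccccn2)/C1=C(\O)OC(C)(C)C` is compound 3 with the same change, (tert-butyl in place of ethyl on an oxygen on an unsaturated carbon), the second time this change occurs here. Since the surroundings of the change are the same in both pairs, a step of about the same size as before is expected, a 2.3-fold lower number from compound 3 to compound 4 (0.36 log units; beyond the scatter), resting on compound 2 against compound 1 through a 2.3-fold lower number from compound 1 to compound 2 (0.36 log units; beyond the scatter). Compound 4 is therefore estimated at 10000 nM, between 4000 nM and 25000 nM.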

Compound 4, half-maximal effective concentration: 1810000 nM
Compound 4: middle estimate off by 180-fold (2.26 log units), on the low side, outside the stated range (above it).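

In this assay, tert-butyl in place of ethyl gives a 79-fold higher number from compound 3 to compound 4 (1.90 log units; beyond the scatter), and the two steps for this change disagree: the same change on two cores in this assay, a 2.3-fold lower number (0.36 log units; beyond the scatter) from compound 1 to compound 2 and a 79-fold higher number (1.90 log units; beyond the scatter) from compound 3 to compound 4, 180-fold (2.26 log units) apart, beyond the scatter of two such steps. Pyridin-2-yl in place of pyridin-4-yl gives a 640-fold higher number from compound 2 to compound 4 (2.81 log units; beyond the scatter), and this change also differs between its two cores: the same change on two cores in this assay, a 3.5-fold higher number (0.55 log units; beyond the scatter) from compound 1 to compound 3 and a 640-fold higher number (2.81 log units; beyond the scatter) from compound 2 to compound 4, 180-fold (2.26 log units) apart, beyond the scatter of two such steps. In this series, then, neither step carried over from one core to the other, even in direction for the ethyl to tert-butyl change, but two pairs cannot show why this happens or predict the step on a further core.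

On these data alone, it remains open whether isopropyl or a longer chain such as n-butyl on the same oxygen would follow the same split. As far as these compounds go, it also remains open how phenyl on a saturated ring carbon would behave with ethyl and with tert-butyl.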